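Swapping Trifluoromethyl for Fluoro on a Quinazolinone Side Ring

The compounds below may be only part of what the source reports. "The series", "measured", "known", "first", "only" and "open" are said of these compounds alone.

Measured so far:
Compound 1 `Cc1cccc(-c2nc3ccc(C)cc3c(=O)[nH]2)c1` gives 12.7% in an assay on isolated protein for inhibition of DNA topoisomerase 1 (Homo sapiens), with a stated time of 30 min, tested at 20 uM; on this read-out higher numbers stand for a stronger effect at the one concentration tested and lower numbers for a weaker effect.
Compound 2 `Cc1ccc2nc(-c3cccc(C(F)(F)F)c3)[nH]c(=O)c2c1` gives 4.2% in this assay.
Compound 3 `O=c1[nH]c(-c2cccc3ccccc23)nc2ccc(N3CCCCC3)cc12` gives 33.4% in this assay.

Compound 2 sits at the low end of these three numbers. Its value and that of compound 1 lie within the scatter of each other, while compound 3 stands beyond the scatter above it. Compound 4 `Cc1ccc2nc(-c3cccc(F)c3)[nH]c(=O)c2c1` differs from compound 2 in one place: fluoro in place of trifluoromethyl on an aromatic carbon. Going by the values given here, the only measured step touching this position is a number 8.5 percentage points lower from compound 1 to compound 2 (within the scatter), which stayed within the scatter. Among the compounds with values here, no measured compound carries fluoro, so the expectation rests on that small step alone. The change is therefore expected to give a number 4.8 percentage points higher from compound 2 to compound 4 (within the scatter), nothing beyond the scatter. Compound 4 is estimated at 9%, within a range of 0% to 22%.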

Compound 4, a percentage reported as inhibition, at one concentration (the size of the read-out at that concentration, not a potency): 0.2%
Beside the measured number, compound 4's estimate is 8.8 percentage points above it, within the range that was stated.
By their numbers in this assay, from the lowest: compounds 4, 2 and 1 (each within the scatter of the next, the first and the last beyond it); then compound 3.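

In this assay, fluoro in place of trifluoromethyl gives a number 4 percentage points lower from compound 2 to compound 4 (within the scatter), so these two groups cannot be told apart at this position. Fluoro in place of methyl gives a number 12.5 percentage points lower from compound 1 to compound 4 (beyond the scatter), the first step at this position to pass the scatter, though only modestly. No supporting evidence explains this difference.

Going by these compounds, whether a hydroxyl, an amine or a carboxylic acid on this aromatic carbon would raise the read-out remains open. So does whether the gap between methyl and fluoro holds at other concentrations.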